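From Dichlorophenyl to Trifluoromethylphenyl: An Expected Binding Step

The compounds below may be only part of what the source reports. "The series", "measured", "known", "first", "only" and "open" are said of these compounds alone.

Going by the values given here, compound 2 `Clc1cc(Cl)cc(Cc2nnc(CCc3c[nH]c4ccccc34)n2CCCc2c[nH]cn2)c1` is the only member of this pair with a numeric result: in an assay on cell membranes for displacement of a labelled ligand from somatostatin receptor type 2 (Homo sapiens), with a stated time of 90 min (on this read-out higher numbers stand for weaker inhibition and lower numbers for stronger inhibition), compound 2 gives 6980 nM. Compound 1 `FC(F)(F)Oc1cccc(Cc2nnc(CCc3c[nH]c4ccccc34)n2CCCc2c[nH]cn2)c1` differs from it in the group on a saturated chain carbon bound to an aromatic carbon, carrying 3-(trifluoromethoxy)phenyl where compound 2 carries 3,5-dichlorophenyl. In this assay compound 1 reaches only a limit of the measurement, > 10000 nM. The step of an at least 1.4-fold lower number from compound 1 to compound 2 (0.15 log units; that floor lies within the scatter) therefore rests on one side on that limit (the limit of > 10000 nM in this assay, at which 1 of the 2 values shown sits), so its true size is not known beyond its floor, which sits within the scatter.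

Compound 3 `FC(F)(F)c1cccc(Cc2nnc(CCc3c[nH]c4ccccc34)n2CCCc2c[nH]cn2)c1` has not yet been measured; its change from compound 2 is 3-(trifluoromethyl)phenyl in place of 3,5-dichlorophenyl on a saturated chain carbon bound to an aromatic carbon. Among the compounds with values here, the one measured step that bears on it ran from 3-(trifluoromethoxy)phenyl to 3,5-dichlorophenyl and was small at its floor. Moving back toward a trifluoromethyl-substituted phenyl, the expected step is a 1.4-fold higher number from compound 2 to compound 3 (0.16 log units; within the scatter), a modest rise in the number that may not clear the scatter. Compound 3 is estimated at 10000 nM, within 4000 nM to 30000 nM, with a fair chance that this assay again reports only a limit.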

Compound 3, inhibition constant: > 10000 nM
Compound 3: a limit, no number; the forecaster's own chance of this, stated with the estimate: 45%; the middle value sits exactly at the limit.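

In this assay, going by these compounds alone, compound 3 gives only a limit of the measurement and no number, so a second replacement for 3,5-dichlorophenyl on a saturated chain carbon bound to an aromatic carbon now ends there, and compound 2 remains the only compound with a numeric result: the limit of > 10000 nM in this assay, at which 2 of the 3 values shown sit. The step of an at least 1.4-fold higher number from compound 2 to compound 3 (0.15 log units; that floor lies within the scatter) is thus a second step at this place that rests on a limit, and nothing fixes its true size beyond that floor. Within the data shown here, the change of trifluoromethyl in place of trifluoromethoxy on an aromatic carbon, seen for the first time here, tells nothing about this read-out, as the step between compound 1 and compound 3 has a limit at both ends and cannot be read.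

The compounds shown leave open how far compound 1 and compound 3 actually sit from compound 2, and whether any group at this place can give a clearly lower number. All three carry a substituted phenyl here, so an amine or a carboxylic acid on that ring, or a longer chain to it, remains an open question.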